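Amino in Place of Dimethylamino on Two Cores

The source may report more compounds than this note shows. Statements on the series, on what has been measured and on what is new or still open speak of the compounds shown alone.

Compound 1 `CN(C)C(=S)N/N=C/c1ccc2cccnc2n1` and compound 3 `CN(C)C(=S)N/N=C/c1cnc2ccccc2n1` are built from the same atoms joined differently; the difference between the two cores is not broken down here. In a functional assay on HL-60 cells (Homo sapiens) for antiproliferative activity, read by sulforhodamine B assay, with a stated time of 72 h (on this read-out lower numbers stand for stronger inhibition and higher numbers for weaker inhibition), compound 1 gives 560 nM. Compound 3 gives 90 nM in this assay. Compound 2 `NC(=S)N/N=C/c1ccc2cccnc2n1` carries the change (amino in place of dimethylamino on a thiocarbonyl carbon). In this assay compound 2 reaches only > 100000 nM, which is a limit of the assay (the limit of > 100000 nM in this assay, at which 1 of the 3 values shown sits). The step of an at least 170-fold higher number from compound 1 to compound 2 (2.25 log units; beyond the scatter) is thus a large one. Compound 4 `NC(=S)N/N=C/c1cnc2ccccc2n1` carries the same change on the core of compound 3: amino in place of dimethylamino on a thiocarbonyl carbon. Compound 4 is expected to show a step of a 440-fold higher number from compound 3 to compound 4 (2.65 log units; beyond the scatter) in this assay, an expectation resting on the measured step of an at least 170-fold higher number from compound 1 to compound 2 (2.25 log units; beyond the scatter). Compound 4 is accordingly estimated at 40000 nM, with a range from 4000 nM to 200000 nM, and the result may well be reported only as a limit.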

Compound 4, half-maximal inhibitory concentration: > 100000 nM
Compound 4 gave a limit, no number (the forecaster's own chance of this, stated with the estimate: 55%); middle value at least 2.5-fold (0.39 log units) away from the limit.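

In this assay the change from dimethylamino to amino gives a large step towards weaker inhibition on the second core as well, with an at least 1100-fold higher number from compound 3 to compound 4 (3.04 log units; beyond the scatter). The value of compound 4, > 100000 nM, is a limit of the assay and not a number. The direction of the change therefore holds on both cores shown, but its size cannot be compared between them: the same change on two cores in this assay, an at least 170-fold higher number (2.25 log units; beyond the scatter) from compound 1 to compound 2 and an at least 1100-fold higher number (3.04 log units; beyond the scatter) from compound 3 to compound 4; the limit leaves it open whether they differ

The compounds shown leave open how methylamino, or a ring amine such as pyrrolidine or morpholine, on the thiocarbonyl carbon would read on either core. On these data alone, how far compound 2 and compound 4 lie beyond the limit also stays open.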